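This account rests on a few compounds, and the source may have more. Where it says the series, first, only, none or still open, it means among the compounds named here.

In a functional assay on the whole organism (blood, strain albino) with Mus musculus as the target, with stated times of 6 days and 3 h, at a dose of 1 mmol/kg by the oral route (a higher number here means more inhibition at the dose given (going by the name of the read-out), a lower number less inhibition), compound 1 `Cc1cc(C(=O)O)nn1-c1ccc(S(=O)(=O)N2CCC(=O)N(C3CCCCC3)C2=S)cc1` gives 2%. Compound 2 `Cc1cc(C)n(-c2ccc(S(=O)(=O)N3CCC(=O)N(C4CCCCC4)C3=S)cc2)n1` gives 4% in this assay, and compound 3 `CCN1C(=O)CCN(S(=O)(=O)c2ccc(-n3nc(C(=O)O)cc3C)cc2)C1=S` gives 1%. Both measured steps are small: a number 2 percentage points higher from compound 1 to compound 2 (within the scatter) and a number 1 percentage points lower from compound 1 to compound 3 (within the scatter). Compound 2 therefore stands within the scatter of compound 1 and of compound 3 alike, so the three numbers cannot be told apart.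

Compound 4 `Cc1cc(C)n(-c2ccc(S(=O)(=O)N3CCC(=O)N(c4ccccc4)C3=S)cc2)n1` differs from compound 2 in one place: phenyl in place of cyclohexyl on an amide-type nitrogen in a ring. The step that bears on this is the one at the same amide-type ring nitrogen, a number 1 percentage points lower from compound 1 to compound 3 (within the scatter), which stayed within the scatter when one group replaced another there. Nothing else in the measured set touches this position. The expectation for compound 4 is therefore no change beyond the scatter, an estimated step of no change at the digits printed from compound 2 to compound 4 (within the scatter). Compound 4 is expected to give 4% in this assay, within a range of 0% to 12%.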

Compound 4, a percentage reported as inhibition, in the whole organism at one dose (the size of the read-out at that dose, not a potency): < 1%
Compound 4 was reported as a limit (the forecaster's own chance of this, stated with the estimate: 0%); at least 3 percentage points between middle value and limit.
By their numbers in this assay, from the lowest: compounds 3, 1 and 2 (each within the scatter of the next).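

Replacing the non-aromatic cyclohexyl ring with the aromatic phenyl ring, which has the same count of heavy atoms, gives a number at least 3 percentage points lower from compound 2 to compound 4 (that floor lies within the scatter). Among these compounds, this is the first change at the amide-type nitrogen in a ring to set a carbon-only aromatic ring there, and like the ethyl step, it does not show a change beyond the scatter. Compound 4 is reported as a limit of the assay rather than as a number, so the true size of this step cannot be read: the limit of < 1% in this assay, at which 1 of the 4 values shown sits.

Still open, on these data alone, is whether any group at this nitrogen, such as benzyl or a longer alkyl chain like butyl, would move the number in this assay beyond the scatter. An amine or a hydroxyl group on the phenyl ring of compound 4 is equally untested among the compounds shown.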